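This account rests on a few compounds, and the source may have more. Where it says the series, first, only, none or still open, it means among the compounds named here.

This account follows two measured compounds and a third whose result is not yet in hand. Compound 1 `CN1C[C@H](NC(=O)OCCCCC2CCCCC2)C1=O` and compound 2 `CSCCCON1C(=O)[C@@H](NC(=O)OCCCCC2CCCCC2)[C@@H]1C` share the same core. In an assay on HEK293 cells for inhibition of N-acylethanolamine-hydrolyzing acid amidase (Homo sapiens), read by fluorescence, with stated times of 10 min and 50 min (a lower number here means a stronger inhibitor, a higher number a weaker inhibitor), compound 2 gives 167 nM, the lower of the two numbers recorded. In this assay, for the measured compounds named here, compound 1 gives 1980 nM, a higher number whose distance from compound 2 lies beyond the usual scatter, so compound 2 is the stronger inhibitor of the two measured so far. Compound 3 `C[C@H]1[C@H](NC(=O)OCCCCC2CCCCC2)C(=O)N1Oc1ccccc1` keeps the core of compound 2 and changes only the group on the oxygen: phenyl in place of 3-(methylsulfanyl)propyl on an oxygen. Going by the values given here, no step between measured compounds isolates this change, so nothing measured constrains its size or direction. The expected 1.5-fold lower number from compound 2 to compound 3 (0.18 log units; within the scatter) is small and may amount to no change beyond the scatter. The estimate for compound 3 in this assay is 110 nM, within a range from 25 nM to 500 nM, pending the actual measurement.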

Compound 3, half-maximal inhibitory concentration: 23 nM
Compound 3: middle estimate off by 4.8-fold (0.68 log units), on the high side; the measured number lies below the stated range.
By their numbers in this assay, from the lowest: compound 3; then compound 2; then compound 1.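

In this assay, phenyl in place of 3-(methylsulfanyl)propyl on an oxygen whose other neighbours are an amide-type nitrogen in a ring gives a 7.3-fold lower number from compound 2 to compound 3 (0.86 log units; beyond the scatter), the first step shown between compounds that differ in one place, and it shows that the number responds to the group held at this position. The exchange removes an open chain containing sulfur and brings in a six-membered aromatic ring of carbon only. This single step ties the lower number to the whole exchange and not to either feature alone. Nothing at hand offers a measured account of why the number falls, so the step stands as an observation only.

The compounds shown leave open whether the aromatic ring itself matters or whether losing the sulfur would be enough, a question that a pentyl chain or a benzyl group on the same oxygen would help to separate. They also leave open how far the number would move with a chlorophenyl or methoxyphenyl group at this position, and so whether phenyl marks a limit or only one point in a longer series.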